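Shortening the ether-linked oxane on a Bcl-2 sulfonamide

The compounds below may be only part of what the source reports. "The series", "measured", "known", "first", "only" and "open" are said of these compounds alone.

Measured so far:
compound 1 `CN1CCC(CNc2ccc(S(=O)(=O)NC(=O)c3ccc(N4CCN(CC5=C(c6ccc(C(F)(F)F)cc6)CC(C)(C)CC5)CC4)cc3Oc3cnc4[nH]ccc4c3)cc2[N+](=O)[O-])C1`: 2.4 nM
compound 2 `CC1(C)CCC(CN2CCN(c3ccc(C(=O)NS(=O)(=O)c4ccc(NCC5CCOC5)c([N+](=O)[O-])c4)c(Oc4cnc5[nH]ccc5c4)c3)CC2)=C(c2ccc(C(F)(F)F)cc2)C1`: 4.7 nM
compound 3 `CC1(C)CCC(CN2CCN(c3ccc(C(=O)NS(=O)(=O)c4ccc(OCC5CCOCC5)c([N+](=O)[O-])c4)c(Oc4cnc5[nH]ccc5c4)c3)CC2)=C(c2ccc(C(F)(F)F)cc2)C1`: 1 nM

All three were tested in an assay on isolated protein for displacement of a labelled ligand from Apoptosis regulator Bcl-2 (Homo sapiens), with a stated time of 15 min; on this read-out higher numbers stand for weaker inhibition and lower numbers for stronger inhibition. Compound 3 gives the lowest number of the three. Its steps to the others, a 2.4-fold lower number from compound 1 to compound 3 (0.38 log units; beyond the scatter) and a 4.7-fold lower number from compound 2 to compound 3 (0.67 log units; beyond the scatter), both lie beyond the scatter, and it is the strongest of the set. The step from compound 3 to compound 4 `CC1(C)CCC(CN2CCN(c3ccc(C(=O)NS(=O)(=O)c4ccc(OC5CCOCC5)c([N+](=O)[O-])c4)c(Oc4cnc5[nH]ccc5c4)c3)CC2)=C(c2ccc(C(F)(F)F)cc2)C1` is oxan-4-yl in place of (oxan-4-yl)methyl on an oxygen on an aromatic ring; the same difference, cut one bond further out, reads (oxan-4-yl)methoxy to (oxan-4-yl)oxy. Among the compounds with values here, none of the measured steps touches this point: they swap the ring attached to the side chain (a 2.0-fold higher number from compound 1 to compound 2 (0.29 log units; within the scatter)) or exchange the amine link for the ether (a 2.4-fold lower number from compound 1 to compound 3 (0.38 log units; beyond the scatter), a 4.7-fold lower number from compound 2 to compound 3 (0.67 log units; beyond the scatter)), and all keep the bridge that is removed here. Within the data shown here, with no step bearing on it, the expectation is a change within the scatter, if anything a slightly higher number, so compound 4 is estimated at 1.6 nM (range 0.5 nM to 5 nM), an expected step of a 1.6-fold higher number from compound 3 to compound 4 (0.20 log units; within the scatter).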

Compound 4, half-maximal inhibitory concentration: 8.4 nM
Beside the measured number, compound 4's estimate is 5.3-fold (0.72 log units) below it, and the stated range ends below it.
By their numbers in this assay, from the lowest: compound 3; then compounds 1, 2 and 4 (each within the scatter of the next, the first and the last beyond it).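

Shortening (oxan-4-yl)methoxy to (oxan-4-yl)oxy is not a neutral trim in this assay: it gives an 8.4-fold higher number from compound 3 to compound 4 (0.92 log units; beyond the scatter) and is the largest step in the set, so the length of the link at this position matters. The ether oxygen alone does not secure a low number, since the result is level with an amine-linked side chain in one comparison (a 1.8-fold higher number from compound 2 to compound 4 (0.25 log units; within the scatter)) and falls behind another, beyond the scatter (a 3.5-fold higher number from compound 1 to compound 4 (0.54 log units; beyond the scatter)). Nothing measured here accounts for the size of this loss.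

On these data alone, whether the same shortening costs as much with an amine link, as in (oxan-4-yl)amino, stays open. So does whether a longer chain, such as 2-(oxan-4-yl)ethoxy, would keep or lower the number.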